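The source may hold more compounds than are shown below. What is called first, only, known or untested is meant among the compounds shown, and "the series" means these compounds.

Compound 1, with the structure `CC(C)[C@@H]1CC[C@@H](C)C[C@@]12N(C)C(=O)[C@@H]1[C@H]3C(=O)N(C)C(=O)[C@H]3ON12`, was tested in a functional assay, with a stated time of 20 min, tested at 2.5 mg/mL (a higher number here means a stronger effect of the compound at the concentration tested, a lower number a weaker effect), where compound 1 gives 55.8%. Within the data shown here, the one other measured compound, compound 2 with the structure `COc1ccc(N2C(=O)[C@H]3[C@H](ON4[C@@H]3C(=O)N(C)[C@@]43C[C@H](C)CC[C@H]3C(C)C)C2=O)cc1`, gives in this assay 65.3%, so compound 1 has one of only two numbers, and the other number sits within the usual scatter of it: the step of a number 9.5 percentage points higher from compound 1 to compound 2 (within the scatter) does not separate the two compounds.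

Compound 3, with the structure `Cc1cccc(N2C(=O)[C@H]3[C@H](ON4[C@@H]3C(=O)N(C)[C@@]43C[C@H](C)CC[C@H]3C(C)C)C2=O)c1`, has not yet been measured. It differs from compound 1 in one place, (3-methylphenyl in place of methyl on an amide-type nitrogen in a ring). Among the measured compounds shown here, the only measured step that bears on this change is the one from compound 1 to compound 2, where a 4-methoxyphenyl replaced the same methyl, and that step stayed within the scatter. A step of similar size or none at all is therefore expected here, in this assay, as a number 6.2 percentage points higher from compound 1 to compound 3 (within the scatter). Compound 3 is accordingly estimated to give 62%, in a range from 48% to 76%.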

Compound 3, a percentage reported as activity, at one concentration (the size of the read-out at that concentration, not a potency): 57.6%
Compound 3: middle estimate off by 4.4 percentage points, on the high side, and the stated range covers the measured number.
By their numbers in this assay, from the lowest: compounds 1, 3 and 2 (each within the scatter of the next).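

In this assay the amide-type nitrogen now carries a 3-methylphenyl, and replacing the single carbon of methyl with this group of seven carbons and a six-membered aromatic ring gives a number 1.8 percentage points higher from compound 1 to compound 3 (within the scatter) and so leaves the read-out unchanged within the scatter. Exchanging one substituted phenyl for another gives a number 7.7 percentage points lower from compound 2 to compound 3 (within the scatter) and shows that 3-methylphenyl and 4-methoxyphenyl cannot be told apart at this position in this assay. No supporting measurement is available to interpret these results.

Still open, as far as these compounds go, is whether a different kind of group on this nitrogen, such as a carboxylic acid or a longer chain ending in an amine, would move the read-out beyond the scatter. Also open, from the compounds shown here alone, is whether moving a single substituent around the phenyl ring matters, since the methyl and methoxy groups here differ in both identity and place.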